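This account rests on a few compounds, and the source may have more. Where it says the series, first, only, none or still open, it means among the compounds named here.

Compound 1, `Cc1[nH]c2ccccc2c1C1=CCC(NCc2ccc(OCC(=O)NO)cc2F)CC1`: 99 nM
Compound 2, `Cc1ccc2[nH]cc(C3=CCN(Cc4ccc(OCC(=O)NO)cc4)CC3)c2c1`: 632 nM
Compound 3, `O=C(COc1ccc(CNC2CC=C(c3c[nH]c4ccc(F)cc34)CC2)c(F)c1)NO`: 261 nM

All three were tested in a functional assay on HCT-116 cells (Homo sapiens) for antiproliferative activity, with a stated time of 72 h; a lower number here means a stronger inhibitor, a higher number a weaker inhibitor. Among them compound 1 gives the lowest number, 99 nM; compound 3 gives 261 nM and compound 2 gives 632 nM, and both of those differences from compound 1 lie beyond the scatter. Compound 4, `Cc1[nH]c2cccc(F)c2c1C1=CCC(NCc2ccc(OCC(=O)NO)cc2F)CC1`, has not yet been measured. It differs from compound 1 in a single place: fluoro in place of hydrogen on an aromatic carbon, the new fluoro sitting on a six-membered aromatic ring of carbon only within the fused two-ring system, ortho to a fused ring. Among the compounds with values here, the only measured step that touches this part of the shared core is a 2.6-fold higher number from compound 1 to compound 3 (0.42 log units; beyond the scatter), but that step swaps the whole 2-methyl-1H-indol-3-yl group for 5-fluoro-1H-indol-3-yl, a change at more than one spot, so it bears only loosely on the single fluoro added in compound 4. Nothing else among the three compounds speaks to this position. A small step is therefore expected in this assay, leaning toward a slightly higher number, as a 1.4-fold higher number from compound 1 to compound 4 (0.15 log units; within the scatter). Compound 4 is estimated at 140 nM, with a likely range from 60 nM to 350 nM.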

Compound 4, half-maximal inhibitory concentration: 254 nM
Compound 4: the middle estimate sits 1.8-fold (0.26 log units) below what was measured; low and high end bracket the measured number.
By their numbers in this assay, from the lowest: compound 1; then compounds 4 and 3 (each within the scatter of the next); then compound 2.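

In this assay, placing one fluoro in place of hydrogen on the six-membered aromatic ring, ortho to a fused ring, gives a 2.6-fold higher number from compound 1 to compound 4 (0.41 log units; beyond the scatter) and so moves the number beyond the scatter. This position is therefore sensitive to a change as small as one added fluorine atom in compound 4. The earlier step, a 2.6-fold higher number from compound 1 to compound 3 (0.42 log units; beyond the scatter), changed more than one spot at once and could not show this effect on its own, and nothing shown explains why the number rises here.

Going by these compounds, it remains open whether chloro, methoxy or an amine at this same place would give a higher or lower number than fluoro. Also open, on these data alone, is how a 5-fluoro-2-methyl-1H-indol-3-yl group would compare, since it would help separate the two changes made between compound 1 and compound 3.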